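From Chloro to Bromo on a Shared Core

The compounds below may be only part of what the source reports. "The series", "measured", "known", "first", "only" and "open" are said of these compounds alone.

In a functional assay on SNO cells (Homo sapiens) for cytotoxicity, read by XTT assay, with a stated time of 24 h (on this read-out higher numbers stand for weaker inhibition and lower numbers for stronger inhibition), compound 1 `COc1cc(C)c(Cl)c2c1C(=O)C=CC2=O` gives 24600 nM, and compound 2 `Cc1cc(O)c2c(c1Cl)C(=O)C=CC2=O` gives 17200 nM. Among the measured compounds shown here, compound 2 therefore stands level with compound 1, since the only measured step, a 1.4-fold lower number from compound 1 to compound 2 (0.16 log units; within the scatter), replaces a methyl on an oxygen with hydrogen and stays within the usual scatter. Compound 3 `Cc1cc(O)c2c(c1Br)C(=O)C=CC2=O` differs from compound 2 in one place: bromo in place of chloro on an aromatic carbon. The swap is bromo in place of chloro on an aromatic carbon, para to a hydroxy group. For the measured compounds named here, no measured step varies this halogen, so the one step available bears on it only loosely, as a small change elsewhere on the core. No shift beyond the scatter is therefore expected in this assay. The estimated step is a 1.1-fold lower number from compound 2 to compound 3 (0.06 log units; within the scatter). Compound 3 is expected near 15000 nM, with an estimated range of 7000 nM to 32000 nM.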

Compound 3, half-maximal inhibitory concentration: 14900 nM
Estimate against measurement, compound 3: 1.0-fold (0.00 log units) above, and the stated range covers the measured number.
By their numbers in this assay, from the lowest: compounds 3, 2 and 1 (each within the scatter of the next).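

Compound 1 and compound 2 both carry chloro on this aromatic carbon, para to a hydroxy group in compound 2, so they could say nothing about the halogen itself. In this assay, bromo in place of chloro gives a 1.2-fold lower number from compound 2 to compound 3 (0.06 log units; within the scatter), so chloro and bromo cannot be told apart here, and this read-out leaves this change without a visible effect on the shared core. No measurement at hand offers an explanation for this result.

From the compounds shown here alone, two halogens say little about how this carbon responds to other kinds of group, so the effect of an amine, a nitrile or a longer chain there remains open. Also open, going by these compounds, is whether bromo would read the same alongside a methoxy group in place of the hydroxy group.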